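The source may report more compounds than this note shows. Statements on the series, on what has been measured and on what is new or still open speak of the compounds shown alone.

Compound 3 `Cc1cncc(Cl)c1N1CCN(C(=O)CCS(=O)(=O)c2cccc3ncsc23)CC1` offers no number to start from: in an ADME assay on microsomes from liver (Rattus norvegicus) for metabolic stability, read by LC-MS, with a stated time of 15 min, tested at 1 uM (on this read-out higher numbers stand for a more stable compound and lower numbers for a less stable compound), compound 3 is recorded as "not determined" (no result reported). As far as these compounds go, its place on the scale is therefore unknown, and any comparison with it stays open.

Compound 4 `N#Cc1ccc(N2CCN(C(=O)CCS(=O)(=O)c3cccc4ncsc34)CC2)nc1` departs from compound 3 in a single place: 5-cyanopyridin-2-yl in place of 3-chloro-5-methylpyridin-4-yl on an amine nitrogen in a ring. The shared core and the amide chain stay as they are, and 5-cyanopyridin-2-yl stands in place of 3-chloro-5-methylpyridin-4-yl on an amine nitrogen in a ring.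

The nearest measured compounds are compound 1 `O=C(CCS(=O)(=O)c1cccc2ncsc12)N1CCN(c2ccc(C(F)(F)F)cn2)CC1`, at 41% in this assay, and compound 2 `O=C(CCS(=O)(=O)c1cccc2ncsc12)N1CCN(c2ccc(Cl)cn2)CC1`, at 31%. Going by the values given here, the one measured step joining them is a number 10 percentage points lower from compound 1 to compound 2 (within the scatter), with chloro in place of trifluoromethyl on an aromatic carbon. That step does not start from compound 3 and does not involve a nitrile, so it bears on the change only indirectly, as a sign of how far one substituent exchange has moved the read-out in this small set.

Among the compounds with values here, no step from compound 3 can be sized, and compound 4 is expected to differ from compound 1 and compound 2 by no more than the usual scatter. For compound 4, the estimated value is 35%, with an expected range from 18% to 55%.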

Compound 4, percent of the compound remaining: 59%
Compound 4: the middle estimate sits 24 percentage points below what was measured; the measured number lies above the stated range.
By their numbers in this assay, from the lowest: compounds 2 and 1 (each within the scatter of the next); then compound 4.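

Compound 4 shows that the aromatic carbon bearing the substituent on the pyridine can carry a change that moves the read-out beyond the scatter, which the earlier pair, compound 1 and compound 2, did not show. In this assay, cyano in place of chloro gives a number 28 percentage points higher from compound 2 to compound 4 (beyond the scatter), and cyano in place of trifluoromethyl gives a number 18 percentage points higher from compound 1 to compound 4 (beyond the scatter), so the nitrile stands apart from both earlier substituents, on the higher side of the scale. The change from 3-chloro-5-methylpyridin-4-yl to 5-cyanopyridin-2-yl itself cannot be read, as compound 3 has no result, and nothing available accounts for the higher number of compound 4.

As far as these compounds go, it remains open whether a methoxy group or a primary carboxamide on the same aromatic carbon would read with the nitrile or with chloro and trifluoromethyl. From the compounds shown here alone, it also remains open whether the nitrile would keep its standing on a pyridine attached as in compound 3, or with a longer chain in place of the present amide chain.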